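Replacing an Attached Imidazole by a Linked Triazole

This account rests on a few compounds, and the source may have more. Where it says the series, first, only, none or still open, it means among the compounds named here.

Of the compounds shown here, three have been measured in an assay on CHO cells for agonist activity at 5-hydroxytryptamine receptor 1D (Homo sapiens), read by GTPgammaS binding; on this read-out higher numbers stand for an effect only at larger amounts of compound and lower numbers for an effect already at smaller amounts. Compound 1 `c1ccc(CNCC2CCN(CCCc3c[nH]c4ccc(-n5cnnc5)cc34)CC2)cc1` gives 5.6 nM. Compound 2 `OC[C@H](NC1CCN(CCCc2c[nH]c3ccc(-n4ccnc4)cc23)CC1)c1ccccc1` gives 0.8 nM, and compound 3 `COC[C@H](NC1CCN(CCCc2c[nH]c3ccc(-n4cnnc4)cc23)CC1)c1ccccc1` gives 0.9 nM. Compound 2 shows the lowest of the three numbers, but compound 3 sits within the scatter of it, so the two cannot be ranked; compound 1 lies furthest from compound 2, beyond the scatter.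

Compound 4 `OC[C@H](NC1CCN(CCCc2c[nH]c3ccc(Cn4cncn4)cc23)CC1)c1ccccc1` has not yet been measured. It differs from compound 2 in one place: (1H-1,2,4-triazol-1-yl)methyl in place of 1H-imidazol-1-yl on an aromatic carbon.

Going by the values given here, the one step that has been measured, a 6.2-fold lower number from compound 1 to compound 3 (0.79 log units; beyond the scatter), concerns the amine side of the molecule and leaves the aromatic substituent untouched, so it does not bear on this change. Compounds 2 and 3 differ in two places at once, one of them being the ring on the aromatic carbon, and their two values lie within the scatter of each other. Among the compounds with values here, no measured step therefore speaks directly to exchanging the attached imidazole for a linked triazole, and the expectation is a step of at most modest size in this assay, with no clear direction.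

On that basis compound 4 is estimated at 2 nM, within a range from 0.5 nM to 8 nM. The expected step is a 2.5-fold higher number from compound 2 to compound 4 (0.40 log units; beyond the scatter).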

Compound 4, half-maximal effective concentration: 32 nM
Compound 4: the middle estimate sits 16-fold (1.20 log units) below what was measured, and the stated range ends below it.
By their numbers in this assay, from the lowest: compounds 2 and 3 (each within the scatter of the next); then compound 1; then compound 4.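

In this assay, putting (1H-1,2,4-triazol-1-yl)methyl in place of 1H-imidazol-1-yl on this aromatic carbon gives a 40-fold higher number from compound 2 to compound 4 (1.60 log units; beyond the scatter) as a large step. This is the first single change at this position among the compounds shown, and it reveals that the position does not accept every ring-bearing group equally: the amine side is the same in both compounds, so the whole step belongs to this one substituent. The exchange alters two things together, since the entering group adds a methyl link between the ring and the aromatic carbon and also carries a five-membered ring with 3 hetero atoms instead of 2, and no measurement on hand explains the size of the step.

What remains open is which of those two alterations accounts for the step, a question that (1H-imidazol-1-yl)methyl or a directly attached 1H-1,2,4-triazol-1-yl at the same position could help to separate. Also open, from the compounds shown here alone, is whether the step would have a similar size with another amine side, such as the (2-methoxy-1-phenylethyl)amino group, in place of the one carrying the free hydroxyl.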